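This account rests on a few compounds, and the source may have more. Where it says the series, first, only, none or still open, it means among the compounds named here.

Working notes on the series. Compound 1 `CC1=CC[C@@H]([C@@](C)(O)CCCC(C)(C)NC(=S)NN)CC1` is the parent; in a functional assay on UACC-62 cells (Homo sapiens) for cytotoxicity, read by sulforhodamine B assay (a lower number here means a stronger inhibitor of growth, a higher number a weaker inhibitor of growth), compound 1 gives a limit rather than a number, > 100000 nM. Going by the values given here, compound 2 `CC1=CC[C@@H]([C@@](C)(O)CCCC(C)(C)NC(=S)N/N=C\c2ccc(C)cc2)CC1` extends the terminal nitrogen; in this assay compound 2 gives 39000 nM, the only number in the set. Among the compounds with values here, the one recorded step is an at least 2.5-fold lower number from compound 1 to compound 2 (0.40 log units; beyond the scatter), read against (the limit of > 100000 nM in this assay, at which 1 of the 2 values shown sits).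

Compound 3 `COc1ccc(/C=N\NC(=S)NC(C)(C)CCC[C@](C)(O)[C@@H]2CC=C(C)CC2)cc1` differs from compound 2 only by methoxy in place of methyl on an aromatic carbon. Within the data shown here, no measured pair varies a substituent on that ring, and the recorded step from compound 1 to compound 2 concerns the whole aryl group against a limit, so it gives no direction for a methyl-to-methoxy exchange. In this assay no step beyond the scatter is expected; the estimated step is a 1.1-fold lower number from compound 2 to compound 3 (0.05 log units; within the scatter). Compound 3 is therefore expected near 35000 nM, with a range from 15000 nM to 85000 nM.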

Compound 3, concentration for total growth inhibition: 22100 nM
The estimate for compound 3 lay 1.6-fold (0.20 log units) above the measured number, and the stated range covers the measured number.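

In this assay, the exchange of methyl for methoxy on an aromatic carbon para to a large group gives a 1.8-fold lower number from compound 2 to compound 3 (0.25 log units; within the scatter), so at this position the two substituents cannot be told apart. Measured against the parent, the 4-methoxyphenyl group gives an at least 4.5-fold lower number from compound 1 to compound 3 (0.65 log units; beyond the scatter), which means a second aryl group on the terminal nitrogen also stands beyond the scatter from compound 1. Compound 1 gives a limit and not a number, so this step is a bound only: the limit of > 100000 nM in this assay, at which 1 of the 3 values shown sits.

As far as these compounds go, whether a substituent such as chloro, nitro or an amine at this ring carbon would move the number beyond the scatter remains open. The compounds shown also leave open what a carboxylic acid at this position would do, and how much of the remaining growth inhibition depends on the aryl ring itself.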